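Swapping hydroxy for trifluoromethyl on a pyrrolidine

The source may report more compounds than this note shows. Statements on the series, on what has been measured and on what is new or still open speak of the compounds shown alone.

Measured in a physicochemical assay for solubility, read by HPLC, in phosphate buffer, at pH 6.5; a higher number here means a more soluble compound, a lower number a less soluble compound:
compound 1 `COC(=O)C1=C(CN2CCCCC2)NC(c2nccs2)=NC1(C)c1ccc(F)cc1` gives 282 ug/mL
compound 2 `COC(=O)C1=C(CN2CCC(O)C2)NC(c2nccs2)=NC1(C)c1ccc(F)cc1` gives 503 ug/mL

Compound 2 stands level with compound 1, as the two numbers lie within the usual scatter of each other. Among the measured compounds shown here, the one measured step is a 1.8-fold higher number from compound 1 to compound 2 (0.25 log units; within the scatter), and it put 3-hydroxypyrrolidin-1-yl in place of piperidin-1-yl.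

Compound 3 `COC(=O)C1=C(CN2CCC(C(F)(F)F)C2)NC(c2nccs2)=NC1(C)c1ccc(F)cc1` has trifluoromethyl in place of hydroxy on a saturated ring carbon. The measured step changed the ring as well, so it is only a partial guide. Compound 1, which also has no hydroxy, gives 282 ug/mL, so a modest step to a lower number is expected in this assay, near the edge of the scatter. The expected step is a 2.3-fold lower number from compound 2 to compound 3 (0.36 log units; beyond the scatter). Compound 3 is estimated at 220 ug/mL, with an expected range of 70 ug/mL to 500 ug/mL.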

Compound 3, solubility: 13 ug/mL
Compound 3: the middle estimate sits 17-fold (1.23 log units) above what was measured; the whole stated range lies above it.
By their numbers in this assay, from the lowest: compound 3; then compounds 1 and 2 (each within the scatter of the next).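

In this assay the saturated ring carbon two ring bonds from the ring nitrogen turns out to matter far more than the earlier pair could show: trifluoromethyl in place of hydroxy there gives a 39-fold lower number from compound 2 to compound 3 (1.59 log units; beyond the scatter) and this is a large step, whereas the earlier step between compounds lay within the scatter. Losing the hydroxy cannot be the whole story, since compound 1 also has none and still stands level with compound 2, while 3-(trifluoromethyl)pyrrolidin-1-yl in place of piperidin-1-yl gives a 22-fold lower number from compound 1 to compound 3 (1.34 log units; beyond the scatter) as a second large step. No measurement shown here explains why the number falls so far.

The compounds shown leave open where a single fluorine, a methoxy group or an amine on the same ring carbon would fall between compound 2 and compound 3. They also leave open whether trifluoromethyl would give a similar number on the piperidine ring of compound 1.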